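Amide nitrogen substituent swap in a quinoline-ether amide series

The source may hold more compounds than are shown below. What is called first, only, known or untested is meant among the compounds shown, and "the series" means these compounds.

Measured so far:
- compound 1 `Cc1cc(C)cc(NC(=O)COc2cc(C)nc3ccccc23)c1`: 55000 nM
- compound 2 `COc1ccc2nc(C)cc(OCC(=O)NCc3cc(C)cc(C)c3)c2c1`: 92000 nM
- compound 3 `COc1ccc2nc(C)cc(OCC(=O)Nc3cc(OC)c(OC)c(OC)c3)c2c1`: 34000 nM

Three compounds of the shared core have been run in a physicochemical assay for solubility, in phosphate buffer, measured as kinetic solubility, with a stated time of 1 h, at pH 7.4; on this read-out lower numbers stand for lower solubility and higher numbers for higher solubility. Compound 2 gives the highest of the three numbers. Its nearest neighbour is compound 1, whose value is within the scatter of that of compound 2, so no order between the two can be read. Compound 3 sits furthest away; its value is beyond the scatter from that of compound 2. Among the compounds with values here, no pair of measured compounds differs in a single place, so no step within the measured set can be isolated.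

The next compound to be run is compound 4 `COc1ccc2nc(C)cc(OCC(=O)Nc3ccncc3)c2c1`. Against compound 2 the change is pyridin-4-yl in place of 3,5-dimethylbenzyl on an amide-type nitrogen. Nothing measured in the set shows this particular exchange, so the expectation rests on the value of compound 2 and on the size of the spread among the three numbers. The step is estimated as a 1.0-fold lower number from compound 2 to compound 4 (0.01 log units; within the scatter), that is, no change beyond the scatter is expected in either direction. For compound 4 a value of 90000 nM is estimated, with a range from 40000 nM to 160000 nM.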

Compound 4, solubility: 91500 nM
Compound 4: middle estimate off by 1.0-fold (0.01 log units), on the low side, within the range that was stated.
By their numbers in this assay, from the lowest: compounds 3, 1, 4 and 2 (each within the scatter of the next, the first and the last beyond it).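

Working notes on the amide nitrogen: in this assay the exchange of 3,5-dimethylbenzyl for pyridin-4-yl gives a 1.0-fold lower number from compound 2 to compound 4 (0.00 log units; within the scatter) and is the first single-place step in the series. The earlier compounds shown here could not isolate any substituent on this amide-type nitrogen, whereas this pair shows that the two groups cannot be told apart on this read-out, even though they differ in size, in ring composition and in the hydrogen-bond acceptor counted on pyridin-4-yl. No supporting measurement is available to account for this result, so the step stands as an observation on one pair only.

One step cannot define the tolerance of the position, and the result says nothing about whether other aromatic groups, such as pyridin-3-yl or a phenyl ring bearing a carboxylic acid, would also stay within the scatter of compound 2. Also open, on these data alone, is how a non-aromatic substituent on the same nitrogen, such as a longer alkyl chain ending in a dimethylamino group, would read in this assay when set against compound 2 or compound 4.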